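Swapping a sulfonyl for a sulfide on a pyridine-fused lactam

The compounds below may be only part of what the source reports. "The series", "measured", "known", "first", "only" and "open" are said of these compounds alone.

Compound 1, `CC1(C)C(=O)N(c2ccc(S(C)(=O)=O)cc2)c2ncccc21`, gives 0% in a functional assay on the whole organism (Pleural cavity) for inhibition, with Rattus norvegicus as the target, at a dose of 25 mg/kg (a lower number here means less inhibition, a higher number more inhibition at the dose given (going by the name of the read-out)), the lowest of the two numbers recorded. Compound 2, `CC1(C)C(=O)N(Cc2ccccc2)c2ncccc21`, gives 12% in this assay, a value that lies beyond the scatter above compound 1. Compound 3, `CSc1ccc(N2C(=O)C(C)(C)c3cccnc32)cc1`, has not been measured; it differs from compound 1 in one place, (methylsulfanyl in place of methylsulfonyl on an aromatic carbon). Among the measured compounds shown here, no measured pair shows this change, so the expectation rests on compound 1 alone. A small rise within the scatter is expected, a step of a number 8 percentage points higher from compound 1 to compound 3 (within the scatter). Compound 3 is therefore estimated to give 8%, between 0% and 25%.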

Compound 3, a percentage reported as inhibition, in the whole organism at one dose (the size of the read-out at that dose, not a potency): 37%
Estimate against measurement, compound 3: 29 percentage points below; measured number outside the range, above it.
By their numbers in this assay, from the lowest: compound 1; then compound 2; then compound 3.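

Methylsulfanyl in place of methylsulfonyl on this aromatic carbon, para to a large group, gives a number 37 percentage points higher from compound 1 to compound 3 (beyond the scatter) in this assay. With the rest of compound 1 unchanged, this single position can therefore strongly alter the inhibition seen at this dose. Nothing available explains why this exchange has so large an effect.

As far as these compounds go, it remains open whether the gain is particular to methylsulfanyl. A methoxy group, an amine or a longer chain such as ethylsulfanyl at this position could show how narrow the requirement is.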